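The source may hold more compounds than are shown below. What is called first, only, known or untested is meant among the compounds shown, and "the series" means these compounds.

Measured so far:
- Compound 1 `COc1cc2c(Oc3ccc(NC(=O)c4nn(-c5ccc(C)cc5C)cc(C)c4=O)cc3)ccnc2cc1OCCCCCCC(=O)NO`: 1840 nM
- Compound 2 `COc1cc2c(Oc3ccc(NC(=O)c4nn(-c5ccccc5C)cc(C)c4=O)c(F)c3)ccnc2cc1OCCCCCCC(=O)NO`: 4280 nM
- Compound 3 `COc1cc2c(Oc3ccc(NC(=O)c4nn(-c5ccccc5)cc(C)c4=O)cc3F)ccnc2cc1OCCCCCC(=O)NO`: 4170 nM

In a functional assay on A549 cells (Homo sapiens) for inhibition, read by MTT assay, with a stated time of 72 h (a lower number here means a stronger inhibitor, a higher number a weaker inhibitor), compound 1 stands lowest of the three at 1840 nM, making it the strongest inhibitor measured so far. Compound 2 and compound 3 both lie above it, each by a margin beyond the scatter.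

The next compound, compound 4 `COc1cc2c(Oc3ccc(NC(=O)c4nn(-c5ccccc5)cc(C)c4=O)cc3)ccnc2cc1OCCCCCCC(=O)NO`, keeps the rest of compound 1 but carries phenyl in place of 2,4-dimethylphenyl on an aromatic nitrogen. For the measured compounds named here, no pair of measured compounds isolates this change, so the data give no direct measure of its size. The expectation is therefore modest: a small move in this assay towards a higher number, no larger than the usual scatter. The estimated step is a 1.3-fold higher number from compound 1 to compound 4 (0.12 log units; within the scatter), and a wide margin remains on either side. For compound 4 the expected value is 2400 nM, with an estimated range from 1100 nM to 5200 nM.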

Compound 4, half-maximal inhibitory concentration: 420 nM
For compound 4 the middle estimate is 5.7-fold (0.76 log units) above the measured one; measured number below the stated range.
By their numbers in this assay, from the lowest: compound 4; then compound 1; then compounds 3 and 2 (each within the scatter of the next).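

For the compounds shown here, compounds 1 and 4 form the first pair that differs only in the group on the aromatic nitrogen, and this position proves sensitive in this assay. Replacing 2,4-dimethylphenyl with phenyl gives a 4.4-fold lower number from compound 1 to compound 4 (0.64 log units; beyond the scatter), a step beyond the scatter, so the bare phenyl ring is the better of these two groups here. The compounds shown include no measurement that explains this step.

It remains open whether one methyl group alone accounts for the step, as no pair shown separates the 2-methyl from the 4-methyl group on an otherwise unchanged compound. It is also unknown how this position would respond to a different ring substituent, such as a fluorine atom, a methoxy group or an amine, or to a pyridyl ring in place of phenyl.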